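Ester-bearing aryl group replaces methoxyphenyl on the cyclopentane carbon

The source may hold more compounds than are shown below. What is called first, only, known or untested is meant among the compounds shown, and "the series" means these compounds.

Compound 1 `COc1ccc(C2(CNC(=O)Nc3c(C(C)C)cccc3C(C)C)CCCC2)cc1` sits in the middle of a closely grouped trio. In an assay on microsomes for inhibition of acyl-CoA:cholesterol acyltransferase (Oryctolagus cuniculus) (a higher number here means a weaker inhibitor, a lower number a stronger inhibitor), compound 1 gives 31 nM, the second highest of the three numbers. Its nearest neighbour is compound 3 `CC(C)c1cccc(C(C)C)c1NC(=O)NCC1(c2ccc(N)cc2)CCCC1`, which gives 29 nM; the furthest is compound 2 `CC(C)c1cccc(C(C)C)c1NC(=O)NCC1(c2ccc(OCc3ccccc3)cc2)CCCC1`, which gives 34 nM. Every measured step among them stays within the scatter: a 1.1-fold lower number from compound 1 to compound 3 (0.03 log units; within the scatter), a 1.1-fold higher number from compound 1 to compound 2 (0.04 log units; within the scatter) and a 1.2-fold lower number from compound 2 to compound 3 (0.07 log units; within the scatter). Compound 4 `COC(=O)c1cccc(C2(CNC(=O)Nc3c(C(C)C)cccc3C(C)C)CCCC2)c1` has not yet been measured. It differs from compound 1 in one place: 3-(methoxycarbonyl)phenyl in place of 4-methoxyphenyl on a saturated ring carbon. For the measured compounds named here, no measured step changes the group on the saturated ring carbon in this way; the steps from compound 1 to compound 2 and compound 3 only show that swapping the substituent on the aromatic carbon leaves this assay essentially unmoved. On that slender basis the step of a 1.3-fold higher number from compound 1 to compound 4 (0.11 log units; within the scatter) is expected to be small, most likely within the scatter, with a slight lean toward a higher number. Compound 4 is therefore estimated at 40 nM, with a range from 15 nM to 110 nM.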

Compound 4, half-maximal inhibitory concentration: 34 nM
Estimate against measurement, compound 4: 1.2-fold (0.07 log units) above; low and high end bracket the measured number.
By their numbers in this assay, from the lowest: compounds 3, 1, 2 and 4 (each within the scatter of the next).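

In this assay, for the compounds shown here, the whole aryl group on the saturated ring carbon is exchanged for the first time, not just a substituent on the aromatic carbon, and the result is a 1.1-fold higher number from compound 1 to compound 4 (0.04 log units; within the scatter) and, against the amine, a 1.2-fold higher number from compound 3 to compound 4 (0.07 log units; within the scatter) within the same series. This position therefore accepts 3-(methoxycarbonyl)phenyl as well as the aryl groups of compounds 1, 2 and 3, with no step among these shown beyond the scatter. Nothing available accounts for how closely these numbers agree.

The compounds shown leave open whether a carboxylic acid or an amide in place of the methyl ester would stay in this range. They also leave open what a saturated group such as cyclohexyl would do in place of the aromatic ring on this carbon.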